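Compound 2 and a reshaped chain in compound 3

A few compounds are considered here, and "the series" means these few. Any claim that something is new, unique, unknown or untested is made for them only; others in the source may bear on it.

Compound 1 `O=S(=O)(c1ccccc1)c1c(OCCCCCCO)no[n+]1[O-]` gives "not determined" (no result reported)
Compound 2 `O=C(COCCOc1no[n+]([O-])c1S(=O)(=O)c1ccccc1)NO` gives 15100 nM

Within the data shown here, in a functional assay on MDA cells (Homo sapiens) for inhibition, read by MTT assay, with a stated time of 48 h (a lower number here means a stronger inhibitor, a higher number a weaker inhibitor), compound 2 gives 15100 nM as the only number available, so it cannot yet be ranked against another compound. Compound 3 (`O=C(/C=C/COc1no[n+]([O-])c1S(=O)(=O)c1ccccc1)NO`) keeps the shared core but alters the chain (2-(hydroxycarbamoyl)ethenyl in place of ((hydroxycarbamoyl)methoxy)methyl on a saturated chain carbon bound to an oxygen on an aromatic ring). In words, 2-(hydroxycarbamoyl)ethenyl stands in place of ((hydroxycarbamoyl)methoxy)methyl on a saturated chain carbon bound to an oxygen on an aromatic ring. Among the measured compounds shown here, no measured pair shows what such a change does, so any forecast here is loose. No step beyond the scatter is expected in this assay, with only a slight lean toward a lower number. The estimated move is a 1.5-fold lower number from compound 2 to compound 3 (0.18 log units; within the scatter) as an expectation only. For compound 3 the estimate is 10000 nM with an expected range from 2500 nM to 40000 nM in this measurement.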

Compound 3, half-maximal inhibitory concentration: 47700 nM
Compound 3: middle estimate off by 4.8-fold (0.68 log units), on the low side; the whole stated range lies below it.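

Placing 2-(hydroxycarbamoyl)ethenyl in the spot held by ((hydroxycarbamoyl)methoxy)methyl, on a saturated chain carbon bound to an oxygen on an aromatic ring, gives a 3.2-fold higher number from compound 2 to compound 3 (0.50 log units; beyond the scatter) in this assay and so a weaker inhibitor. This first measured step shows that this place is sensitive to the make-up of the chain, even though the shared core and the hydroxycarbamoyl end stay in both compounds. Nothing available explains why the number rises. The step also bundles two differences, one oxygen fewer and one more double bond outside aromatic rings, and the compounds shown do not separate them. Also open, going by these compounds, is whether a carboxylic acid or an amine at the end of this chain would give a lower or a higher number.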